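The source may report more compounds than this note shows. Statements on the series, on what has been measured and on what is new or still open speak of the compounds shown alone.

Working notes on a set of adenosine-type compounds carrying a substituted benzylamino group, tested in a functional assay on B16 cells (Mus musculus) for antiproliferative activity, with a stated time of 72 h; on this read-out lower numbers stand for stronger inhibition and higher numbers for weaker inhibition.

Compound 1 `Cc1ccc(CNc2ncnc3c2ncn3[C@@H]2O[C@H](CO)[C@@H](O)[C@H]2O)cc1` has no result in this assay: "not determined" (no result reported). Compound 3 `COc1ccc(CNc2ncnc3c2ncn3[C@@H]2O[C@H](CO)[C@@H](O)[C@H]2O)c(OC)c1` likewise has no result in this assay: "not determined" (no result reported). Compound 2 `COc1ccccc1CNc1ncnc2c1ncn2[C@@H]1O[C@H](CO)[C@@H](O)[C@H]1O` gives only a limit in this assay, > 166000 nM, and not a number. So compound 3 stands without a number of its own; of the three entries for this assay, one is the limit of > 166000 nM in this assay, at which 1 of the 3 values shown sits, and one carries no result at all.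

Compound 4 `COc1cccc(CNc2ncnc3c2ncn3[C@@H]2O[C@H](CO)[C@@H](O)[C@H]2O)c1O` is not yet measured. It differs from compound 3 in one place: 2-hydroxy-3-methoxyphenyl in place of 2,4-dimethoxyphenyl on a saturated chain carbon bound to a nitrogen on an aromatic ring.

For the measured compounds named here, no measured step between two compounds in this assay is available to set the size of this change. Given that the one value reported is a limit, the expectation for compound 4 in this assay is a weak or unresolved result, with no step beyond the scatter that can be argued for. Compound 4 is expected to give about 150000 nM, in a range from 30000 nM to 600000 nM.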

Compound 4, half-maximal inhibitory concentration: > 166000 nM
Compound 4 was reported as a limit; the forecaster's own chance of this, stated with the estimate: 70%; middle value at least 1.1-fold (0.04 log units) away from the limit.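

No step can be read between compound 2 and compound 4 in this assay, as each gives only a limit and not a number: the limit of > 166000 nM in this assay, at which 2 of the 4 values shown sit.

The compounds shown leave open whether any substituted benzylamino group on the shared core gives a number rather than a limit in this assay.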